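The compounds below may be only part of what the source reports. "The series", "measured", "known", "first", "only" and "open" are said of these compounds alone.

Measured in a functional assay on SNU-638 cells (Homo sapiens) for cytotoxicity, read by sulforhodamine B assay, with a stated time of 72 h; on this read-out lower numbers stand for stronger inhibition and higher numbers for weaker inhibition:
- Compound 1 `OCC1=C(F)[C@@H](n2cnc3c(O)ncnc32)[C@H](O)[C@@H]1O`: > 100000 nM, a limit of the assay and not a number
- Compound 2 `CNc1ncnc2c1ncn2[C@@H]1C(F)=C(CO)[C@@H](O)[C@H]1O`: 2280 nM

Going by the values given here, compound 2, at 2280 nM, holds the only true number in this assay, so it cannot yet be ranked against a second number. The other entry is the limit of > 100000 nM in this assay, at which 1 of the 2 values shown sits.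

Compound 3 `OCC1=C(F)[C@@H](n2cnc3c(NC4CC4)ncnc32)[C@H](O)[C@@H]1O` differs from compound 2 by one change: cyclopropyl in place of methyl on a nitrogen on an aromatic ring. This is cyclopropyl in place of methyl on a nitrogen on an aromatic ring, or methylamino to cyclopropylamino.

Among the compounds with values here, only one measured step bears on this change, and only indirectly. The step of an at least 43-fold lower number from compound 1 to compound 2 (1.64 log units; beyond the scatter) is large and beyond the scatter, and it comes with methylamino in place of hydroxy on an aromatic carbon. Compound 3 keeps a substituted amino group at that place, so most of that large gain is expected to survive. Within the data shown here, no measured step exchanges one group on that nitrogen for another, so the size of the new step remains uncertain. A modest weakening is the expectation, with the step estimated as a 2.6-fold higher number from compound 2 to compound 3 (0.42 log units; beyond the scatter). For compound 3 the estimated value is 6000 nM, with an expected range from 1500 nM to 30000 nM.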

Compound 3, half-maximal inhibitory concentration: > 100000 nM
Compound 3: no number, only a limit; the forecaster's own chance of this, stated with the estimate: 15%; at least 16-fold (1.22 log units) between middle value and limit.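

Cyclopropyl in place of methyl on a nitrogen on an aromatic ring gives an at least 43-fold higher number from compound 2 to compound 3 (1.64 log units; beyond the scatter) in this assay and thereby shows that a substituted amino group at this place does not by itself keep the number seen with methylamino. Compound 3 gives > 100000 nM in this assay, a limit of the assay and not a number, and the step between compound 1 and compound 3 cannot be read, since both of its ends are limits. Among the compounds shown, the result therefore leaves compound 2 as the only one with a true number, while compound 1 and compound 3 share the same limit: the limit of > 100000 nM in this assay, at which 2 of the 3 values shown sit.

The compounds shown leave open whether the loss goes with the three-membered ring or with the larger group alone: ethyl or isopropyl on the same nitrogen would separate the two, and a plain amino group would show whether that nitrogen needs a carbon group at all. They also leave open how far the true values of compound 1 and compound 3 lie beyond the limit they share.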